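This account rests on a few compounds, and the source may have more. Where it says the series, first, only, none or still open, it means among the compounds named here.

Measured compounds in an ADME assay on Raji cells (Homo sapiens) for inhibition, with a stated time of 72 h; on this read-out lower numbers stand for an effect already at smaller amounts and higher numbers for an effect only at larger amounts of compound:

compound 1 `O=C(Nc1ccc(Cl)cc1)c1cc([N+](=O)[O-])ccc1Cl` gives > 25000 nM, a limit of the assay.
compound 2 `C=C(C)C(=O)Nc1cccc(-c2nc3ccccc3s2)c1` gives > 25000 nM, a limit of the assay.
compound 3 `CN(C)CCC(=O)Nc1cccc(-c2nc3ccccc3s2)c1` gives > 25000 nM, a limit of the assay.

Compound 3 therefore stands at the limit shared by all three measured compounds, as the limit of > 25000 nM in this assay, at which 3 of the 3 values shown sit, records, and no number separates it from compound 1 or compound 2. Among the measured compounds shown here, the one single-point step recorded, a step that the two limits leave unreadable from compound 2 to compound 3, is unreadable in size since both ends are limits.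

Compound 4 `O=C(Nc1cccc(-c2nc3ccccc3s2)c1)c1cnccc1Cl` differs from compound 3 by 4-chloropyridin-3-yl in place of 2-(dimethylamino)ethyl on a carbonyl carbon. For the measured compounds named here, no measured step bears on this exchange, and the only step touching the same carbonyl carbon was itself unreadable. No direction can be taken from the measured compounds. Compound 4 is therefore expected most probably to sit again at the limit, with a step of a number no higher from compound 3 to compound 4 (the limit leaves the size open) estimated as not beyond the scatter. The estimate for compound 4 is 25000 nM, within 5000 nM to 100000 nM, with a limit being the likely report.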

Compound 4, half-maximal effective concentration: 12000 nM
Compound 4: middle estimate off by 2.1-fold (0.32 log units), on the high side; low and high end bracket the measured number.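

In this assay, the group on the carbonyl carbon proves able to move the read-out: 4-chloropyridin-3-yl in place of 2-(dimethylamino)ethyl gives an at least 2.0-fold lower number from compound 3 to compound 4 (0.31 log units; beyond the scatter), and 4-chloropyridin-3-yl in place of 1-methylethenyl gives an at least 2.0-fold lower number from compound 2 to compound 4 (0.31 log units; beyond the scatter). Among the compounds shown here, the earlier exchange at this carbonyl carbon, between two limits, cannot be read, so compound 4 supplies the first readable change at this place. The number of compound 4 stands alone in the series, with the other compounds at a shared limit: the limit of > 25000 nM in this assay, at which 3 of the 4 values shown sit.

On these data alone, whether the chlorine or the ring nitrogen matters to the step remains open, as the two enter together; a pyridin-3-yl without chlorine or a 4-chlorophenyl on the same carbonyl carbon would separate them. As far as these compounds go, the full size of both steps also stays open, each having a limit at one end.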